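From compound 1 to compound 3: a chain change

The source may hold more compounds than are shown below. What is called first, only, known or untested is meant among the compounds shown, and "the series" means these compounds.

Among the measured compounds shown here, in a functional assay on LNCaP cells (Homo sapiens) for cytotoxicity, read by MTT assay, with a stated time of 72 h (on this read-out lower numbers stand for stronger inhibition and higher numbers for weaker inhibition), compound 1 `CN(C)CCCNc1c(C(=O)NCc2ccc(F)cc2)nc(Br)c2cccnc12` gives 8000 nM as the only true number so far. Compound 2 `NCCCNc1c(C(=O)NCc2ccc(F)cc2)ncc2cccnc12` gives > 10000 nM in this assay and this is a limit of the assay, not a number.

Compound 3 `NCCCCCCNc1c(C(=O)NCc2ccc(F)cc2)nc(Br)c2cccnc12` keeps the core of compound 1 and carries 3-aminopropyl in place of dimethylamino on a saturated chain carbon, three bonds along the chain from a nitrogen on an aromatic ring. Read one bond further out, this is 3-(dimethylamino)propyl to 6-aminohexyl.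

For the measured compounds named here, no measured step covers this change, so the expectation rests on compound 1 at 8000 nM alone. The expected change is small and toward stronger inhibition, estimated as a 1.6-fold lower number from compound 1 to compound 3 (0.20 log units; within the scatter) in this assay and hardly beyond the usual scatter. For compound 3 the estimate is 5000 nM with an expected range from 1500 nM to 15000 nM in this series.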

Compound 3, half-maximal inhibitory concentration: 8000 nM
Estimate against measurement, compound 3: 1.6-fold (0.20 log units) below; the measured number falls inside the stated range.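

Under this assay (the only read-out here), 3-aminopropyl in place of dimethylamino on a saturated chain carbon, three bonds along the chain from a nitrogen on an aromatic ring, gives a flat pair (no change at the digits printed from compound 1 to compound 3 (within the scatter)). This position therefore accepts 6-aminohexyl in place of 3-(dimethylamino)propyl with no separation between the two values. Among the compounds shown here, it is the first readable step, and it shows only that these two chains are not told apart here, not that the chain has no influence in general.

As far as these compounds go, whether a longer chain, or a chain ending in a carboxylic acid, would move the number stays open. Any weakening from this level would soon be hard to read, since the assay has a limit and that limit is not a number: the limit of > 10000 nM in this assay, at which 1 of the 3 values shown sits.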